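A few compounds are considered here, and "the series" means these few. Any claim that something is new, unique, unknown or untested is made for them only; others in the source may bear on it.

Working notes on the series.

Compound 1 `CC/C=C/C=C/CCc1cc(O)c([C@@H]2O[C@H](CO)[C@@H](O)[C@H](O)[C@H]2O)c(O)c1C(=O)OC` is the reference point. Within the data shown here, in a functional assay on RAW264.7 cells (Mus musculus) for inhibition, read by Griess assay, with stated times of 2 h and 12 h (on this read-out lower numbers stand for stronger inhibition and higher numbers for weaker inhibition), compound 1 gives 19000 nM, and this is the only numerical value in the set. Compound 2 `CCC/C=C/C=C\CCc1cc(O)c([C@@H]2O[C@H](CO)[C@@H](O)[C@H](O)[C@H]2O)c(O)c1` is the one other case recorded. In this assay compound 2 gives > 40000 nM, which is a limit of the assay and not a number, as noted in the limit of > 40000 nM in this assay, at which 1 of the 2 values shown sits. Among the measured compounds shown here, since one of the two results is a limit, no step between measured compounds can be drawn, and nothing can be said of compound 2 beyond what its limit shows.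

Compound 3 `CCC/C=C/C=C/CCc1cc(O)c([C@@H]2O[C@H](CO)[C@@H](O)[C@H](O)[C@H]2O)c(O)c1C(=O)OC` has not yet been measured. It differs from compound 1 by methyl in place of hydrogen on a saturated chain carbon, two bonds along the chain from a double-bonded chain carbon. For the measured compounds named here, no measured pair in the set speaks to such a chain extension, so in this assay no step beyond the usual scatter is expected in either direction. The step from compound 1 to compound 3 that is expected is a 1.1-fold lower number from compound 1 to compound 3 (0.05 log units; within the scatter). Compound 3 is accordingly estimated at 17000 nM, with an expected range from 7000 nM to 40000 nM.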

Compound 3, half-maximal inhibitory concentration: > 40000 nM
Compound 3 ended at the assay's limit (the forecaster's own chance of this, stated with the estimate: 20%); at least 2.3-fold (0.37 log units) between middle value and limit.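

In this assay, among these compounds, methyl in place of hydrogen on a saturated chain carbon, two bonds along the chain from a double-bonded chain carbon, gives an at least 2.1-fold higher number from compound 1 to compound 3 (0.32 log units; beyond the scatter), the first step that can be read in the set. Among the compounds shown here, the position is therefore not indifferent to this change: extending the chain end from ethyl to propyl, with the rest of compound 1 unchanged, is enough to lose the one measured number, and the step gives only a lower bound on the size of the loss. Compound 1 now stands alone as the only compound with a number, and any step involving the others cannot be read beyond that bound, with most of the set at the ceiling of the assay: the limit of > 40000 nM in this assay, at which 2 of the 3 values shown sit.

From the compounds shown here alone, how far the chain extension weakens inhibition therefore remains open, as does whether the effect continues or reverses with a longer chain such as butyl in this place. Also open, going by these compounds, is whether a polar end group on the same chain, such as an amine or a carboxylic acid, would bring the value back within the measurable range.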